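The compounds below may be only part of what the source reports. "The series", "measured", "known", "first", "only" and "open" are said of these compounds alone.

Working notes on the series. Among the compounds with values here, in an ADME assay on L1210/0 cells (Mus musculus) for cytotoxicity, with a stated time of 48 h (a higher number here means a weaker inhibitor, a lower number a stronger inhibitor), compound 1 `C=Cc1cn([C@H]2C[C@H](O)[C@@H](CO)O2)c(=O)[nH]c1=O` gives 14200 nM, the only true number so far. Compound 2 `CC1(C)C(CO)CC1Cn1cnc2c(N)nc(N)nc21` gives > 200000 nM, which is a limit of the assay and not a number. Compound 3 `O=c1[nH]c(=O)n(COCCO)cc1/C=C/Br` gives > 200000 nM, again a limit and not a number. Compound 1 therefore stands on the stronger side of both limits.

The next compound is compound 4 `COCC#Cc1cn([C@H]2C[C@H](O)[C@@H](CO)O2)c(=O)[nH]c1=O`, which carries 3-methoxyprop-1-yn-1-yl in place of vinyl on an aromatic carbon of the core of compound 1 (3-methoxyprop-1-yn-1-yl in place of vinyl on an aromatic carbon). Within the data shown here, no measured pair shows this change or any other single change, so the expectation is weakly founded. It rests on compound 1 at 14200 nM. It rests as well on the two limits on the weaker side of that value. A moderate weakening in this assay, beyond the usual scatter, is expected, and the estimated step is a 3.5-fold higher number from compound 1 to compound 4 (0.55 log units; beyond the scatter). A reading at the limit of the assay would not surprise. For compound 4 the estimated value is 50000 nM, with an expected range from 9000 nM to 200000 nM.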

Compound 4, half-maximal inhibitory concentration: > 200000 nM
Compound 4: no number, only a limit; the forecaster's own chance of this, stated with the estimate: 30%; at least 4.0-fold (0.60 log units) between middle value and limit.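

In this assay, within the data shown here, 3-methoxyprop-1-yn-1-yl in place of vinyl on an aromatic carbon of the shared core gives an at least 14-fold higher number from compound 1 to compound 4 (1.14 log units; beyond the scatter), the first single change that can be read. Compound 4 gives > 200000 nM, which is a limit of the assay and not a number. This aromatic carbon is therefore sensitive to the change in this assay, but the true size of the step stays unknown, with only its lower bound fixed by the assay's limit: the limit of > 200000 nM in this assay, at which 3 of the 4 values shown sit.

Going by these compounds, whether the loss goes with the triple bond, the ether oxygen or the longer chain stays open. An ethynyl group or a saturated 3-methoxypropyl chain on the same aromatic carbon is not among the compounds shown, and the series cannot say how either would read.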